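The source may hold more compounds than are shown below. What is called first, only, known or untested is meant among the compounds shown, and "the series" means these compounds.

Compound 1 `CNC(=O)c1cccc(-c2ccc(OC)c(S(=O)(=O)Nc3cccc(NCCNC(=O)c4ccccc4OC)c3)c2)c1` gives 182 nM in an assay on CHO-K1 cells for agonist activity at Orexin receptor type 2 (Homo sapiens), read by a luciferase reporter; on this read-out lower numbers stand for an effect already at smaller amounts and higher numbers for an effect only at larger amounts of compound.
Compound 2 `COc1ccccc1C(=O)NCCNc1cccc(NS(=O)(=O)c2cc(-c3cccc(N)c3)ccc2OC)c1` gives a limit of this assay, > 1000 nM.
Compound 3 `COc1ccc(-c2cccc(C(=O)N(C)C)c2)cc1S(=O)(=O)Nc1cccc(NCCNC(=O)c2ccccc2)c1` gives a limit of this assay, > 10000 nM.

Compound 3 thus stands at the far end of the numbers shown: its value is not a number but the upper limit of this assay (the limit of > 10000 nM in this assay, at which 1 of the 3 values shown sits), and compound 2 likewise sits at a limit (the limit of > 1000 nM in this assay, at which 1 of the 3 values shown sits). Only compound 1 has a measured number. For the measured compounds named here, the one measured step, an at least 5.4-fold higher number from compound 1 to compound 2 (0.73 log units; beyond the scatter), concerns amino in place of methylcarbamoyl on an aromatic carbon and does not touch the part of the molecule changed here. Going by the values given here, compound 1 and compound 3 differ in two places, so their values show only that one is a number and the other a limit.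

Compound 4 `COc1ccc(C(=O)NCCNc2cccc(NS(=O)(=O)c3cc(-c4cccc(C(=O)N(C)C)c4)ccc3OC)c2)cc1` differs from compound 3 by methoxy in place of hydrogen on an aromatic carbon, para to a large group on the benzoyl ring. Among the compounds with values here, no measured step bears on this change. Since compound 3 is already reported only as a limit, the expected step that the limit leaves unreadable from compound 3 to compound 4 is no change beyond the scatter, and compound 4 is estimated at 15000 nM in this assay, with a range from 3000 nM to 60000 nM, most likely again reported as a limit.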

Compound 4, half-maximal effective concentration: 1050 nM
Compound 4: middle estimate off by 14-fold (1.15 log units), on the high side; measured number below the stated range.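

Compound 3 is reported only as a limit, > 10000 nM in this assay, so the size of the change can be read in one direction only. Methoxy in place of hydrogen on an aromatic carbon, para to a large group on the benzoyl ring, gives an at least 9.5-fold lower number from compound 3 to compound 4 (0.97 log units; beyond the scatter), a step beyond the scatter that brings the series from a limit to a measured number, and it is the first measured step to show that this end of the molecule matters, since the earlier step concerned the other aryl ring. The data shown offer no measured property that accounts for this gain.

As far as these compounds go, what remains open is whether the gain belongs to methoxy itself or would also come with another group at the same place, such as ethoxy, hydroxyl, fluorine or a dimethylamino group. The compounds shown also leave open how this methoxy would combine with the methylcarbamoyl group or with a second methoxy on the benzoyl ring, since no listed pair isolates either combination in one place.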